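The compounds below may be only part of what the source reports. "The series", "measured", "known", "first", "only" and "open" are said of these compounds alone.

Measured compounds:
- compound 1, `Cc1ccc(NC(=O)c2c(NO)cc(-c3ccc(Cl)cc3)oc2=O)cc1`: > 20000 nM in an ADME assay on Huh-7 cells (Homo sapiens) for cytotoxicity, read by a luciferase reporter and WST assay, with a stated time of 3 days; on this read-out lower numbers stand for higher toxicity in this test and higher numbers for lower toxicity in this test
- compound 2, `O=C(NCc1ccccc1)c1c(NO)cc(-c2ccccc2)oc1=O`: > 20000 nM in this assay

In this assay compound 2 gives only a limit of the assay, > 20000 nM, and not a number. Compound 1 gives the same kind of limit in this test, > 20000 nM. Both measured values therefore rest at the limit of > 20000 nM in this assay, at which 2 of the 2 values shown sit, so compound 2 stands where every measured compound stands, and nothing separates the two compounds on the numbers shown.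

Compound 3, `O=C(NCc1ccccc1)c1c(NO)cc(-c2ccc(Cl)cc2)oc1=O`, is the unmeasured compound. It differs from compound 2 in one place: chloro in place of hydrogen on an aromatic carbon. The same change, seen one bond further out, reads phenyl to 4-chlorophenyl.

Within the data shown here, no step between measured compounds is available for this change. Compound 1, which also carries a chloro group on a six-membered aromatic ring of carbon only, gives a limit in this assay, and compound 2 does the same, so no step beyond the scatter is expected for the chloro for hydrogen exchange. The estimated step that the limit leaves unreadable from compound 2 to compound 3 from compound 2 to compound 3 is expected to be within the scatter. Compound 3 is estimated at 30000 nM, with a range from 12000 nM to 100000 nM, and the test is expected most likely to report only a limit again.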

Compound 3, half-maximal cytotoxic concentration: > 20000 nM
Compound 3: only a limit was reported (the forecaster's own chance of this, stated with the estimate: 80%); the middle value lies beyond the limit too.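

In this assay compound 3 gives > 20000 nM as a limit and not a number. Among these compounds, no step from compound 2 or compound 1 to compound 3 can be read, and nothing orders the three compounds: the limit of > 20000 nM in this assay, at which 3 of the 3 values shown sit. The compounds shown leave open what number any of them would reach in this assay and whether chloro in place of hydrogen changes it at all.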